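The compounds below may be only part of what the source reports. "The series", "measured", "known", "first", "only" and "open" are said of these compounds alone.

Measured compounds:
- Compound 2 `S=C(N/N=C/c1ccc(Oc2ccccc2)cc1)Nc1ccccc1`: 4.9
- Compound 1 `Cc1cc(Oc2ccc(/C=N/NC(=S)Nc3ccc(F)cc3)cc2)ccc1Cl`: 6.07

The two measured compounds were examined in a physicochemical assay for lipophilicity, in phosphate buffer, measured as octanol-water partition, with a stated time of 24 h; a lower number here means a more polar compound, a higher number a more lipophilic compound. For the measured compounds named here, compound 2 stands at the lower of the two numbers with 4.9, and the only neighbour, compound 1, lies well above it, by a gap that is beyond the usual scatter of this assay.

The step considered here leads from compound 2 to compound 3 `Cc1cc(Oc2ccc(/C=N/NC(=S)Nc3ccccc3)cc2)ccc1Cl`, which has not yet been measured. The change is 4-chloro-3-methylphenyl in place of phenyl on an oxygen on an aromatic ring. Nothing directly comparable has been measured as a step between two compounds, so the expectation rests on the two numbers shown. Compound 1, which gives 6.07 in this assay, is the nearer reference point, and compound 3 is expected to come out close to that number. The expected step from compound 2 to compound 3 is therefore a number 0.95 log units higher from compound 2 to compound 3 (beyond the scatter), upward and beyond the scatter. For compound 3 the estimate in this assay is 5.85, with a likely range from 5.4 to 6.3.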

Compound 3, partition coefficient: 6.03
Estimate against measurement, compound 3: 0.18 log units below; the range from low to high includes it.
By their numbers in this assay, from the lowest: compound 2; then compounds 3 and 1 (each within the scatter of the next).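

In this assay, 4-chloro-3-methylphenyl in place of phenyl on an oxygen on an aromatic ring gives a number 1.13 log units higher from compound 2 to compound 3 (beyond the scatter), so this change now has a directly read size, and that size is large. Compound 3 also forms a pair with compound 1 that differs in one other place: hydrogen in place of fluoro on an aromatic carbon gives a number 0.04 log units lower from compound 1 to compound 3 (within the scatter), so with 4-chloro-3-methylphenyl on the oxygen this second change does not move the number beyond the scatter. Nothing at hand explains either of these results.

What 4-chlorophenyl or 3-methylphenyl alone would give on the oxygen stays open, so the large step cannot be divided between the chloro and the methyl, and an amine or a carboxylic acid on the phenyl ring in that place is equally unexplored among the compounds shown. Going by these compounds, it also stays open whether hydrogen in place of fluoro on an aromatic carbon would read the same with plain phenyl on the oxygen.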